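A Small Ring Gives Way to a Fluorinated Aromatic Ring

The compounds below may be only part of what the source reports. "The series", "measured", "known", "first", "only" and "open" are said of these compounds alone.

Three compounds share a core that carries an acid-bearing biaryl joined through a short chain to an imidazole. Compound 1 `CCCCc1cnc(CCCc2ccc(-c3ccccc3C(=O)O)cc2)[nH]1` gives 5600 nM in an in vitro functional assay on cells for agonist activity at Bombesin receptor subtype-3 (Homo sapiens), read by luminescence and calcium flux; on this read-out higher numbers stand for an effect only at larger amounts of compound and lower numbers for an effect already at smaller amounts. Compound 3 `CCCCc1cnc(C(CCCC)Cc2ccc(-c3ccccc3C(=O)O)cc2)[nH]1` gives 2660 nM in this assay. Compound 2 `O=C(O)c1ccccc1-c1ccc(CCc2ncc(CC3CCC3)[nH]2)cc1` gives 588 nM in this assay, the lowest of the three numbers; compound 3 stands nearest to it and compound 1 furthest, and both of those gaps lie beyond the usual scatter.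

Compound 4 `O=C(O)c1ccccc1-c1ccc(CCc2ncc(Cc3ccccc3F)[nH]2)cc1` departs from compound 2 in a single place: 2-fluorophenyl in place of cyclobutyl on a saturated chain carbon bound to an aromatic carbon. The change swaps one four-membered non-aromatic ring of carbon only for one six-membered aromatic ring of carbon only, adding three heavy atoms and a fluorine, while the acid and the rest of the core stay as they are. Within the data shown here, no measured pair in this set shows the same change, so the size of the step rests on judgement alone.

The author expects the step from compound 2 to compound 4 to be modest, a 1.2-fold higher number from compound 2 to compound 4 (0.08 log units; within the scatter), in either direction, and not clearly beyond the scatter. For compound 4 the estimated value in this assay is 700 nM, with a range from 200 nM to 2500 nM.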

Compound 4, half-maximal effective concentration: 177 nM
For compound 4 the middle estimate is 4.0-fold (0.60 log units) above the measured one, and the stated range ends above it.
By their numbers in this assay, from the lowest: compound 4; then compound 2; then compound 3; then compound 1.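

Among these compounds, until this result, the set held no pair of compounds differing in one place, so the step of a 3.3-fold lower number from compound 2 to compound 4 (0.52 log units; beyond the scatter) in this assay is the first reading of what a single change does on this core. It shows that the group on a saturated chain carbon bound to an aromatic carbon is not a silent part of the structure: the number moves beyond the usual scatter when 2-fluorophenyl replaces cyclobutyl. It also shows that the six-membered aromatic ring, with its fluorine and its larger count of heavy atoms, is compatible with agonist activity in this assay, as compound 4 gives 177 nM here.

The change replaces the ring and adds the fluorine at once, so the compounds shown cannot divide the step between the two, and a plain phenyl ring without fluorine or a pyridine ring at this place would be needed to separate them. Nothing at hand gives a measured reason for the step.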